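This account rests on a few compounds, and the source may have more. Where it says the series, first, only, none or still open, it means among the compounds named here.

For the measured compounds named here, in a functional assay on Bel-7402 cells (Homo sapiens) for cytotoxicity, read by MTT assay, with a stated time of 48 h (a higher number here means a weaker inhibitor, a lower number a stronger inhibitor), two compounds have numbers so far. Compound 1 `CCn1cc(-c2nc3ccccc3o2)c(=O)c2cc(F)c(N3CCNCC3)nc21` gives 16800 nM, and compound 2 `CCn1cc(-c2nc3ccccc3s2)c(=O)c2cc(F)c(N3CCNCC3)nc21` gives 2400 nM, the lower of the two and therefore the stronger result. Going by the values given here, the single measured step is a 7.0-fold lower number from compound 1 to compound 2 (0.85 log units; beyond the scatter), with 1,3-benzothiazol-2-yl in place of 1,3-benzoxazol-2-yl on an aromatic carbon. Compound 3 `CCn1cc(-c2nc3ccc([N+](=O)[O-])cc3s2)c(=O)c2cc(F)c(N3CCNCC3)nc21` differs from compound 2 by one change, nitro in place of hydrogen on an aromatic carbon. Among the compounds with values here, the measured step is a different kind of change, and no measured pair shows what adding nitro does. It offers only a rough guide to size, so a much larger step would be surprising. The expected step in this assay is small, probably within the scatter and leaning slightly lower: a 1.3-fold lower number from compound 2 to compound 3 (0.12 log units; within the scatter). Compound 3 is expected at about 1800 nM, with an estimated range from 400 nM to 8000 nM.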

Compound 3, half-maximal inhibitory concentration: 24600 nM
The estimate for compound 3 lay 14-fold (1.14 log units) below the measured number; measured number outside the range, above it.
By their numbers in this assay, from the lowest: compound 2; then compounds 1 and 3 (each within the scatter of the next).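

Nitro in place of hydrogen on an aromatic carbon of the fused system's six-membered carbon-only ring brings a 10-fold higher number from compound 2 to compound 3 (1.01 log units; beyond the scatter) in this assay and thus a much weaker result. The earlier step changed the fused ring system itself, whereas this one shows that the carbon-only ring is also sensitive to change: a single added group of three heavy atoms is enough to undo the standing of compound 2 as the stronger compound. Nothing shown here explains why the number rises.

The compounds shown leave open whether this loss belongs to nitro itself or would follow any group on this carbon. An amine, a methoxy group or a chlorine atom at the same place would help separate the two, as would nitro on another carbon of this ring.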